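A few compounds are considered here, and "the series" means these few. Any claim that something is new, unique, unknown or untested is made for them only; others in the source may bear on it.

Compound 2 `CN/C(=N\C1=NC(=O)C(=O)N1C(C)C)Nc1ccc(Cl)c(Cl)c1` carries a methyl on an amine nitrogen, and it was measured in an in vitro ADME assay on microsomes from liver (Homo sapiens) for metabolic stability, read by LC-MS; a higher number here means that the compound lasts longer, a lower number that the compound disappears faster. In this assay compound 2 gives > 1 h, which is a limit of the assay rather than a number. Compound 1 `C=CCON/C(=N\C1=NC(=O)C(=O)N1C(C)C)Nc1ccc(Cl)c(Cl)c1` carries an allyloxy group in place of that methyl. In this assay compound 1 gives > 1 h, again a limit and not a number. The step that the two limits leave unreadable from compound 1 to compound 2 therefore cannot be read, as the limit of > 1 h in this assay, at which 2 of the 2 values shown sit, shows. Compound 3 `CC(C)N1C(=O)C(=O)N=C1/N=C(\NCCCCN1CCCC1)Nc1ccc(Cl)c(Cl)c1` differs from compound 2 as follows: 3-(pyrrolidin-1-yl)propyl in place of hydrogen on a saturated chain carbon bound to an amine nitrogen. Within the data shown here, the one measured step is unreadable, and no measured step bears on this change. The expected step that the limit leaves unreadable from compound 2 to compound 3 is centred on no change beyond the scatter, with wide uncertainty. Compound 3 is estimated to reach 1.2 h in this assay, within a range from 0.4 h to 3 h.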

Compound 3, half-life: > 1 h
Compound 3 gave a limit, no number; the forecaster's own chance of this, stated with the estimate: 50%; the middle value is on the limit's open side.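

In this assay compound 3 gives > 1 h, a limit and not a number. Its steps from compound 1 and compound 2 therefore cannot be read: the limit of > 1 h in this assay, at which 3 of the 3 values shown sit. From the compounds shown here alone, how long each of these three compounds actually lasts, and whether swapping the methyl, allyloxy or 4-(pyrrolidin-1-yl)butyl group changes that, stays open.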